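The source may report more compounds than this note shows. Statements on the series, on what has been measured and on what is new or still open speak of the compounds shown alone.

Within the data shown here, the two compounds measured so far share one core and differ only at the tail of the amide. Compound 1, `Cc1cc(C)cc(S(=O)(=O)c2c(C(=O)NCC(=O)NC(C)c3ccccc3)[nH]c3ccc(Cl)cc23)c1`, was tested in an ADME assay on MT4 cells (Homo sapiens) for cytotoxicity, read by MTT assay (a higher number here means that more compound is tolerated, a lower number that less compound is tolerated), and in that setting compound 1 gives 29400 nM. Compound 2, `Cc1cc(C)cc(S(=O)(=O)c2c(C(=O)NC(C)C(=O)NC(C)c3ccccc3F)[nH]c3ccc(Cl)cc23)c1`, gives 15200 nM in this assay. These two values lie within the usual scatter of each other, so on the numbers at hand compound 1 and compound 2 cannot be told apart, and neither can be called the better tolerated.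

Compound 3, `Cc1cc(C)cc(S(=O)(=O)c2c(C(=O)NCC(=O)NCc3ccncn3)[nH]c3ccc(Cl)cc23)c1`, has not yet been measured. Against compound 1 its structure changes in one place: (pyrimidin-4-yl)methyl in place of 1-phenylethyl on an amide-type nitrogen. Among the measured compounds shown here, no pair of measured compounds shows this change, so its effect on tolerated concentration is unknown from the data. Both measured tails are of similar size, and the two values they give are close, so the expectation is a step of a 1.2-fold higher number from compound 1 to compound 3 (0.08 log units; within the scatter) that stays within the scatter, with at most a modest lean toward a higher number. Compound 3 is therefore estimated at 35000 nM in this assay, with a range from 15000 nM to 80000 nM.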

Compound 3, half-maximal cytotoxic concentration: > 48800 nM
Compound 3 was reported as a limit; the forecaster's own chance of this, stated with the estimate: 30%; middle value at least 1.3-fold (0.14 log units) away from the limit.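

In this assay, among these compounds, this change gives the first readable step at the amide-type nitrogen: an at least 1.6-fold higher number from compound 1 to compound 3 (0.22 log units; that floor lies within the scatter), for (pyrimidin-4-yl)methyl in place of 1-phenylethyl. The earlier pair, compound 1 and compound 2, differed in more than one place and so could say nothing about any single group, whereas this step isolates one exchange, from a six-membered aromatic ring of carbon only to one with 2 hetero atoms, and shows that the exchange leaves the floor of the step within the scatter while its upper end remains unbounded. The true size of the step cannot be given, because the result for compound 3 is a limit of the assay and not a number: the limit of > 48800 nM in this assay, at which 1 of the 3 values shown sits.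

The compounds shown leave open whether the step follows the hetero atoms of the ring or the loss of the branch in 1-phenylethyl, since both change together between compound 1 and compound 3. A plain benzyl group or a (pyridin-4-yl)methyl group on the same nitrogen would separate these two changes.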